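The compounds below may be only part of what the source reports. "The series", "measured", "known", "first", "only" and "open" are said of these compounds alone.

Compound 1 `O=C(NOCc1ccccc1Cl)c1cn(-c2ccccc2)nc1-c1ccccc1` is the weaker of the two compounds measured in a functional assay on HeLa cells (Homo sapiens) for antiproliferative activity, read by MTT assay, with a stated time of 48 h, in the presence of a further agent that is not named here; a lower number here means a stronger inhibitor of growth, a higher number a weaker inhibitor of growth; compound 1 gives 17800 nM, the highest of the two numbers. Within the data shown here, its nearest neighbour is compound 2 `O=C(NOCc1ccc(Cl)cc1Cl)c1cn(-c2ccccc2)nc1-c1ccccc1`, which gives 5100 nM in this assay, and the single measured step, a 3.5-fold lower number from compound 1 to compound 2 (0.54 log units; beyond the scatter), introduces chloro in place of hydrogen on an aromatic carbon.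

Compound 3 `O=C(NOCc1ccccc1Cl)c1cn(-c2ccccc2)nc1-c1ccc(F)cc1` is not yet measured. It differs from compound 1 by fluoro in place of hydrogen on an aromatic carbon, placed on an aromatic carbon of a six-membered aromatic ring of carbon only. Among the measured compounds shown here, no measured step covers this change: the step from compound 1 to compound 2 concerns chloro on a different ring, so it bears on it only loosely. A small shift, if any, is therefore expected, most likely within the scatter. Compound 3 is estimated at 12000 nM in this assay, within 5000 nM to 30000 nM, a step of a 1.5-fold lower number from compound 1 to compound 3 (0.17 log units; within the scatter) expected.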

Compound 3, concentration for 50% growth inhibition: 36400 nM
Estimate against measurement, compound 3: 3.0-fold (0.48 log units) below, outside the stated range (above it).
By their numbers in this assay, from the lowest: compound 2; then compound 1; then compound 3.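

In this assay, the change from phenyl to 4-fluorophenyl gives a 2.0-fold higher number from compound 1 to compound 3 (0.31 log units; beyond the scatter) and so shows that a single fluoro on an aromatic carbon, para to a large group, can weaken growth inhibition. Among these compounds, this is the first measured change to raise the number, whereas the earlier step, a 3.5-fold lower number from compound 1 to compound 2 (0.54 log units; beyond the scatter) in the opposite direction, placed chloro on a different ring, so the two steps describe different places on the core of compound 1. No evidence is available that accounts for this rise.

On these data alone, it remains open whether the rise is particular to fluoro or whether chloro, a methoxy group or an amine at this position would move the number the same way. As far as these compounds go, it is also open whether the same fluoro change would have a similar effect on compound 2.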